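The source may hold more compounds than are shown below. What is called first, only, known or untested is meant among the compounds shown, and "the series" means these compounds.

Going by the values given here, compound 1 `O=C(COc1ccc2cc(C(O)(C(F)(F)F)C(F)(F)F)c(O)cc2c1)Nc1nc2ccccc2s1` is the anchor of the series: in an assay on isolated protein for inhibition of receptor-type tyrosine-protein phosphatase C (Homo sapiens), read by spectrophotometry (on this read-out lower numbers stand for stronger inhibition and higher numbers for weaker inhibition), compound 1 gives 10900 nM, the only number among the three values shown. Compound 2 `CCCNC(=O)COc1ccc2cc(C(O)(C(F)(F)F)C(F)(F)F)c(O)cc2c1`, with propyl in place of 1,3-benzothiazol-2-yl on the amide-type nitrogen, reaches only the limit > 20000 nM in this assay. That step is an at least 1.8-fold higher number from compound 1 to compound 2 (0.26 log units; that floor lies within the scatter), so the effect of removing 1,3-benzothiazol-2-yl cannot be placed more precisely than the limit of > 20000 nM in this assay, at which 1 of the 3 values shown sits. Compound 3 `Oc1cc(-c2ccccc2)ccc1C(O)(C(F)(F)F)C(F)(F)F` likewise reaches only a limit in this assay, > 500000 nM. Compound 4 `CC(C)c1ccc(NC(=O)COc2ccc3cc(C(O)(C(F)(F)F)C(F)(F)F)c(O)cc3c2)cc1` differs from compound 1 by 4-isopropylphenyl in place of 1,3-benzothiazol-2-yl on an amide-type nitrogen. Among the compounds with values here, the only measured step touching this position is the one from compound 1 to compound 2, which trades the ring for a chain; compound 4 instead keeps a six-membered aromatic ring of carbon only on the amide-type nitrogen, so a much smaller step is expected, not clearly beyond the scatter, namely an expected 1.1-fold higher number from compound 1 to compound 4 (0.04 log units; within the scatter). Compound 4 is therefore estimated at 12000 nM in this assay, within a range from 4000 nM to 35000 nM, with some chance that only a limit is returned.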

Compound 4, half-maximal inhibitory concentration: 7800 nM
Beside the measured number, compound 4's estimate is 1.5-fold (0.19 log units) above it; the range from low to high includes it.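

In this assay, the step to 4-isopropylphenyl is a 1.4-fold lower number from compound 1 to compound 4 (0.15 log units; within the scatter), so at this amide-type nitrogen the all-carbon ring and 1,3-benzothiazol-2-yl cannot be told apart, and the nitrogen and sulfur of 1,3-benzothiazol-2-yl are not required in this pair. Going by these compounds alone, replacing propyl with 4-isopropylphenyl gives an at least 2.5-fold lower number from compound 2 to compound 4 (0.40 log units; beyond the scatter), the only step at this position that clears the scatter, which places the chain below the all-carbon ring here. The size of that step is only a floor, since compound 2 sits at a limit: the limit of > 20000 nM in this assay, at which 1 of the 4 values shown sits.

Still open, going by these compounds, is whether a longer chain such as hexyl on the amide-type nitrogen would match either ring. Also open, on these data alone, is what a carboxylic acid or an amine in place of isopropyl would do to the number.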